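A few compounds are considered here, and "the series" means these few. Any claim that something is new, unique, unknown or untested is made for them only; others in the source may bear on it.

Of the compounds shown here, three have been measured in a functional assay on A549 cells (Homo sapiens) for cytotoxicity, read by sulforhodamine B assay, with a stated time of 48 h, tested at 0.01 uM; on this read-out higher numbers stand for a weaker effect at the one concentration tested and lower numbers for a stronger effect. Compound 1 `COc1ccc(-c2cc(/C=C/C(=O)c3ccc(N)cc3)[nH]n2)cc1` gives 101% in this assay. Compound 2 `COc1ccc(-c2cc(/C=C/C(=O)c3ccc(N)cc3)[nH]n2)cc1OC` gives 97%. The change hydrogen in place of methoxy on an aromatic carbon made the step of a number 4 percentage points higher from compound 2 to compound 1 (within the scatter). Compound 3 `COc1cc(C(=O)/C=C/c2cc(-c3cc(OC)c(OC)c(OC)c3)n[nH]2)cc(OC)c1OC` gives 97%, and all three values lie within the scatter of one another. The difference between the core of compound 3 and the core of compound 2 is not broken down here. Compound 4 `COc1ccc(-c2cc(/C=C/C(=O)c3cc(OC)c(OC)c(OC)c3)[nH]n2)cc1OC` has not yet been measured; it arises from compound 3 by hydrogen in place of methoxy on an aromatic carbon. Within the data shown here, this is the same kind of change as the one leading to compound 1, though here the place is also meta to a methoxy group. Because the earlier step of a number 4 percentage points higher from compound 2 to compound 1 (within the scatter) stayed within the scatter, and because compound 3 already gives 97%, the step from compound 3 to compound 4 is expected to be a number 2 percentage points higher from compound 3 to compound 4 (within the scatter). Compound 4 is therefore estimated at 99% in this assay, most likely between 90% and 107%.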

Compound 4, a percentage reported as activity, at one concentration (the size of the read-out at that concentration, not a potency): 101%
Estimate against measurement, compound 4: 2 percentage points below, and the stated range covers the measured number.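

In this assay, hydrogen in place of methoxy on an aromatic carbon gave a number 4 percentage points higher from compound 3 to compound 4 (within the scatter), and the same change can be compared on the two cores: the same change on two cores in this assay, a number 4 percentage points higher (within the scatter) from compound 2 to compound 1 and a number 4 percentage points higher (within the scatter) from compound 3 to compound 4, 0 percentage points apart, within the scatter of two such steps. The change therefore carried across these two cores with no visible difference between the steps. Both steps lie within the scatter, however, so this agreement does not show that the change has any real effect, and a reading at a single concentration says nothing about potency.

The compounds shown leave open whether a hydroxyl group or a chlorine atom at that place would behave in the same way. They also leave open whether the change would matter at a higher concentration.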